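Moving from benzofuranyl to thiophenyl on a shared nucleoside core

This account rests on a few compounds, and the source may have more. Where it says the series, first, only, none or still open, it means among the compounds named here.

Compound 1 `COc1nc(N)nc2c1c(-c1cc3ccccc3o1)cn2[C@@H]1O[C@H](CO)[C@@H](O)[C@H]1O` gives 15500 nM in a functional assay on K562 cells (Homo sapiens), read by MTT assay, with a stated time of 72 h; a higher number here means a weaker inhibitor, a lower number a stronger inhibitor.
Compound 2 `Nc1nc(N)c2c(-c3cc4ccccc4o3)cn([C@@H]3O[C@H](CO)[C@@H](O)[C@H]3O)c2n1` gives > 20000 nM in this assay, a limit of the assay.
Compound 3 `CN(C)c1ncnc2c1c(-c1ccsc1)cn2[C@@H]1O[C@H](CO)[C@@H](O)[C@H]1O` gives > 20000 nM in this assay, also a limit of the assay.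

Going by the values given here, compound 1 holds the only actual number in this assay; the two other values shown are limits, as the limit of > 20000 nM in this assay, at which 2 of the 3 values shown sit, records. Among the compounds with values here, the single measured step is an at least 1.2-fold higher number from compound 1 to compound 2 (0.11 log units; that floor lies within the scatter), an amino in place of methoxy on an aromatic carbon, and its floor lies within the scatter.

Compound 4 `COc1nc(N)nc2c1c(-c1ccsc1)cn2[C@@H]1O[C@H](CO)[C@@H](O)[C@H]1O` differs from compound 1 by thiophen-3-yl in place of 1-benzofuran-2-yl on an aromatic carbon. Within the data shown here, no measured step bears directly on this change; the only compound carrying thiophen-3-yl is compound 3, which sits at the limit of the assay. Compound 4 is therefore expected to give a higher number, most likely a limit as well, with an estimated step of a 1.9-fold higher number from compound 1 to compound 4 (0.29 log units; within the scatter). Compound 4 is estimated at 30000 nM, within a range from 12000 nM to 80000 nM.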

Compound 4, half-maximal inhibitory concentration: > 20000 nM
Compound 4 was reported as a limit (the forecaster's own chance of this, stated with the estimate: 60%); the middle value is on the limit's open side.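

At this position, on an aromatic carbon of a five-membered aromatic ring with 1 nitrogen, thiophen-3-yl in place of 1-benzofuran-2-yl gives an at least 1.2-fold higher number from compound 1 to compound 4 (0.11 log units; that floor lies within the scatter). The floor of this step lies within the scatter, so the change can be neither sized nor called a loss, though it shows that keeping the methoxy group of compound 1 does not bring a number back with thiophen-3-yl on the shared core. Compound 4 is a limit and not a number, which leaves compound 1 with the only actual number in the series: the limit of > 20000 nM in this assay, at which 3 of the 4 values shown sit.

On these data alone, how far compound 4 lies past its limit stays open, and so does the true size of this step. Also open, as far as these compounds go, is whether a phenyl or a furan-2-yl group at this position would give a number in this assay.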